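The compounds below may be only part of what the source reports. "The series", "measured", "known", "first", "only" and "open" are said of these compounds alone.

Compound 3 `COc1cccnc1Nc1cc2[nH]c(-c3cccc(C(F)(F)F)c3)nc2cn1` shares its core with compound 1 `FC(F)(F)c1cccc(-c2nc3cnc(Nc4ccccn4)cc3[nH]2)c1` and compound 2 `COc1cccc(Nc2cc3[nH]c(-c4cccc(C(F)(F)F)c4)nc3cn2)n1`, and all three carry a trifluoromethyl-bearing ring on one side and a substituted aminopyridine on the other. In a physicochemical assay for solubility, using the shake flask method, in phosphate buffer, measured as kinetic solubility, with a stated time of 20 h, at pH 6.5 (a higher number here means a more soluble compound, a lower number a less soluble compound), compound 1 gives only a limit, < 5000 nM. In this assay compound 2 likewise gives a limit, < 5000 nM. In this assay compound 3 also gives a limit, < 5000 nM. Because all three values sit at the limit of < 5000 nM in this assay, at which 3 of the 3 values shown sit, compound 3 cannot be placed above or below the other two on these numbers alone. Compound 4 `COc1ccnc(Nc2cc3[nH]c(-c4cccc(C(F)(F)F)c4)nc3cn2)c1` differs from compound 3 in one place: 4-methoxypyridin-2-yl in place of 3-methoxypyridin-2-yl on a nitrogen on an aromatic ring. The closest measured comparison, which also moves the methoxy group within the same methoxypyridin-2-yl group, is a step that the two limits leave unreadable from compound 2 to compound 3; adding that methoxy group gave a step that the two limits leave unreadable from compound 1 to compound 2 and a step that the two limits leave unreadable from compound 1 to compound 3, both unreadable as well. None of these steps shows a direction, so no change beyond the scatter is expected from compound 3 to compound 4 in this assay, and the step that the limit leaves unreadable from compound 3 to compound 4 is only an estimate. For compound 4 the expected solubility in this assay is 2500 nM, within a range from 500 nM to 8000 nM, most likely reported once more as a limit.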

Compound 4, solubility: < 5000 nM
Compound 4: no number, only a limit; the forecaster's own chance of this, stated with the estimate: 75%; the middle value lies beyond the limit too.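

In this assay compound 4 also gives only a limit, < 5000 nM. Going by these compounds alone, no step from compound 1, compound 2 or compound 3 to compound 4 can be read, because all four share one reading: the limit of < 5000 nM in this assay, at which 4 of the 4 values shown sit. The compounds shown leave open how soluble each one actually is, and whether adding or moving the methoxy group makes any difference.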